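The source may report more compounds than this note shows. Statements on the series, on what has been measured and on what is new or still open speak of the compounds shown alone.

Three compounds built on the shared core were measured in a functional assay on HeLa cells (Homo sapiens) for cytotoxicity, read by MTT assay, with a stated time of 72 h, tested at 10 uM; a higher number here means more inhibition of growth at the concentration tested, a lower number less inhibition of growth. Compound 1 `Cc1ccnc(/C(N)=N/NC(=S)N2CCCC2)c1` gives 67%. Compound 3 `Cc1ccnc(/C(N)=N/NC(=S)N2CCCCCC2)c1` gives 55.8%. Compound 2 `N/C(=N\NC(=S)N1CCSCC1)c1ccccn1` gives 54.5%, the lowest of the three numbers; it lies within the scatter of compound 3 and beyond the scatter below compound 1. No pair of these compounds differs in only one place, so no single step between measured values can be read off.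

Compound 4 `N/C(=N\NC(=S)N1CCOCC1)c1ccccn1` has not yet been measured in this assay. It differs from compound 2 in one place: morpholin-4-yl in place of thiomorpholin-4-yl on a thiocarbonyl carbon. For the measured compounds named here, nothing among the measured compounds shows what such an exchange does, since only compound 2 carries either of these two rings, so the expectation rests on compound 2 alone, whose value is 54.5%. The expected step is a number 6.5 percentage points lower from compound 2 to compound 4 (within the scatter), small and downward, and it may well stay within the scatter. Compound 4 is estimated to give 48%, in a range from 30% to 65%.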

Compound 4, percent growth inhibition at one concentration: 56.3%
The estimate for compound 4 lay 8.3 percentage points below the measured number, and the stated range covers the measured number.
By their numbers in this assay, from the lowest: compounds 2, 3 and 4 (each within the scatter of the next); then compound 1.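

For the compounds shown here, until now, no measured pair isolated a change at this place, on a thiocarbonyl carbon. In this assay, morpholin-4-yl in place of thiomorpholin-4-yl gives a number 1.8 percentage points higher from compound 2 to compound 4 (within the scatter), so exchanging the ring sulfur for an oxygen does not separate these two compounds, even though only that one atom differs between the two rings. No measurement at hand bears on why the two rings give such similar numbers.

Still open, going by these compounds, is what a ring with a further nitrogen, such as piperazin-1-yl or 4-methylpiperazin-1-yl, or an open-chain group such as dimethylamino, would do on the same thiocarbonyl carbon. Also open, on these data alone, is whether the exchange of thiomorpholin-4-yl for morpholin-4-yl would stay this small on the core of compound 1, which carries an extra methyl group.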